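Urea nitrogen substituents on a shared benzothiazole-free core

The source may report more compounds than this note shows. Statements on the series, on what has been measured and on what is new or still open speak of the compounds shown alone.

Measured compounds in a functional assay on A549 cells (Homo sapiens) for antiproliferative activity, read by MTT assay, with a stated time of 72 h; on this read-out lower numbers stand for stronger inhibition and higher numbers for weaker inhibition:
compound 1 `COc1ncc(-c2ccc3nc(NC(=O)NC4CC4)sc3c2)cc1NS(=O)(=O)c1ccc(F)cc1`: 900 nM
compound 2 `CNC(=O)Nc1nc2ccc(-c3cnc(OC)c(NS(=O)(=O)c4ccc(F)cc4)c3)cc2s1`: 1560 nM

Compound 2 stands highest of the two numbers, its nearest neighbour being compound 1; the step of a 1.7-fold higher number from compound 1 to compound 2 (0.24 log units; within the scatter) lies within the scatter. Compound 3 `COc1ncc(-c2ccc3nc(NC(=O)NCCN4CCCCC4)sc3c2)cc1NS(=O)(=O)c1ccc(F)cc1` differs from compound 2 by (piperidin-1-yl)methyl in place of hydrogen on a saturated chain carbon bound to an amide-type nitrogen. Among the measured compounds shown here, the only step measured at this amide-type nitrogen is a 1.7-fold higher number from compound 1 to compound 2 (0.24 log units; within the scatter), which was within the scatter, so the position appears tolerant of change, though a larger group than either measured one has not been tested. No step beyond the scatter is therefore expected in this assay. Compound 3 is expected near 1200 nM (range 400 nM to 4000 nM), a step of a 1.3-fold lower number from compound 2 to compound 3 (0.11 log units; within the scatter).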

Compound 3, half-maximal inhibitory concentration: 330 nM
Compound 3: the middle estimate sits 3.6-fold (0.56 log units) above what was measured; measured number outside the range, below it.
By their numbers in this assay, from the lowest: compound 3; then compounds 1 and 2 (each within the scatter of the next).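

At this amide-type nitrogen, 2-(piperidin-1-yl)ethyl gives a change beyond the scatter in this assay, with a 4.7-fold lower number from compound 2 to compound 3 (0.67 log units; beyond the scatter) and a 2.7-fold lower number from compound 1 to compound 3 (0.44 log units; beyond the scatter). Methyl and cyclopropyl had stayed within the scatter of each other, so the position is not simply indifferent to its substituent, and this change lowers the number. No data shown here offer an explanation for this step. As far as these compounds go, it remains open whether the step follows the ring, its nitrogen or the chain length. 2-(Dimethylamino)ethyl, 2-(morpholin-4-yl)ethyl and 3-(piperidin-1-yl)propyl would help separate these.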